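The compounds below may be only part of what the source reports. "The series", "measured", "known", "first", "only" and "open" are said of these compounds alone.

Three compounds share one core and differ only in the length of the chain attached through a carbonyl. Compound 1 `CCCCCCCCCCCC(=O)Nc1nnc(S[C@@H]2O[C@H](CO)[C@H](O)[C@H](O)[C@H]2O)s1` carries the middle-length chain; in a functional assay on SK-OV-3 cells (Homo sapiens) for cytotoxicity, read by MTT assay, with a stated time of 24 h (on this read-out lower numbers stand for stronger inhibition and higher numbers for weaker inhibition), compound 1 gives "not active" (no number reported), a result reported without a number. Among the compounds with values here, compound 2 `CCCCCCCC(=O)Nc1nnc(S[C@@H]2O[C@H](CO)[C@H](O)[C@H](O)[C@H]2O)s1` carries the shortest chain, and in this assay compound 2 gives 56000 nM, the only number among the measured compounds and a weak one. Compound 3 `CCCCCCCCCCCCCCCCCC(=O)Nc1nnc(S[C@@H]2O[C@H](CO)[C@H](O)[C@H](O)[C@H]2O)s1` has the longest chain and differs from compound 2 by decyl in place of hydrogen on a saturated chain carbon, seven bonds along the chain from a carbonyl carbon. Within the data shown here, no step between measured compounds is available, so the direction can be read only from what the two values show, where the longer chain of compound 1 goes with "not active" (no number reported). On that basis compound 3 is expected to be weaker by a step of a 2.7-fold higher number from compound 2 to compound 3 (0.43 log units; beyond the scatter), with a real chance that only a limit is reported. Compound 3 is estimated at 150000 nM, within 60000 nM to 400000 nM.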

Compound 3, half-maximal inhibitory concentration: "not active" (no number reported)
Nothing numeric was reported for compound 3; there is nothing to compare the estimate with.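

Within the data shown here, with no number reported for compound 3, no step from compound 2 to compound 3 can be read. Nothing shown here offers an explanation for this result. The compounds shown leave open how chain length relates to cytotoxicity, since only compound 2 has a number.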